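From a phenyl amide to a pyridin-2-yl amide

The source may hold more compounds than are shown below. What is called first, only, known or untested is meant among the compounds shown, and "the series" means these compounds.

Results so far in a functional assay on HO8910 cells (Homo sapiens) for inhibition, read by MTT assay, with a stated time of 24 h, tested at 10 ug/mL; on this read-out lower numbers stand for less inhibition of growth and higher numbers for more inhibition of growth at the one concentration tested
compound 1 `O=C(CCCCC(S)CCS)NO` gives 26.2%
compound 2 `O=C(CCCCC(S)CCS)Nc1ccccc1` gives 5.49%

Compound 2 holds the lower of these two numbers, and the gap lies beyond the scatter. Compound 3 `O=C(CCCCC(S)CCS)Nc1ccccn1` keeps the shared core and carries pyridin-2-yl in place of phenyl on an amide-type nitrogen. Among the compounds with values here, one measured step bears on this place: a number 20.7 percentage points lower from compound 1 to compound 2 (beyond the scatter) with phenyl in place of hydroxy on an amide-type nitrogen. That step shows that a swap here can move the number, but it compares no two rings, so no measured step sizes this change. No step beyond the scatter is therefore expected. Compound 2 at 5.49% has little room to fall, so any small shift is more likely upward. The expected change is a number 2.5 percentage points higher from compound 2 to compound 3 (within the scatter) and it stays within the scatter. In this assay compound 3 is estimated at 8% with a range from 0% to 20% around that figure.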

Compound 3, percent growth inhibition at one concentration: "not active" (no number reported)
The entry for compound 3 holds no number; there is nothing to compare the estimate with.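

Within the data shown here, compound 3 is entered as "not active" without a number, so no step from compound 2 to compound 3 can be read. Nothing measured here explains that entry. The compounds shown leave open how far pyridin-2-yl in place of phenyl shifts growth inhibition.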